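Chalcone growth-inhibition notes: aryl for alkyl at the enone

The source may report more compounds than this note shows. Statements on the series, on what has been measured and on what is new or still open speak of the compounds shown alone.

Measured so far in a functional assay on WiDr cells (Homo sapiens) for inhibition, read by sulforhodamine B assay, with a stated time of 48 h; a higher number here means a weaker inhibitor of growth, a lower number a stronger inhibitor of growth:
compound 1 `O=C(/C=C/C1CCCCC1)c1ccccc1`, 21000 nM
compound 2 `O=C(/C=C/c1ccc(Cl)cc1Cl)c1ccccc1`, 20000 nM
compound 3 `CCC(/C=C(\COC(C)=O)C(=O)c1ccccc1)CC`, 52000 nM

Compound 3 carries the highest number of the three in this assay. Its nearest neighbour is compound 1, whose number sits below it by a gap that exceeds the usual scatter, and compound 2 lies a little further down again, also beyond the scatter. Compounds 1 and 2 are within the scatter of each other, so no order is claimed between them.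

Compound 4 `CC(=O)OC/C(=C\c1ccccc1F)C(=O)c1ccccc1` has not yet been measured. It differs from compound 3 in one place: 2-fluorophenyl in place of pentan-3-yl on a double-bonded chain carbon bound to a double-bonded chain carbon. The acetoxymethyl branch on the other double-bonded chain carbon and the benzoyl part are retained.

Both aromatic-substituted members, compound 1 and compound 2, sit below compound 3, so putting an aryl group in the place of the pentan-3-yl group is expected to bring compound 4 down toward their range. The step from compound 3 to compound 4 is therefore expected to be a modest decrease, a 2.1-fold lower number from compound 3 to compound 4 (0.32 log units; beyond the scatter), though the retained acetoxymethyl branch has no measured comparator and the estimate is correspondingly loose. Compound 4 is estimated at 25000 nM in this assay, within 8000 nM to 70000 nM.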

Compound 4, concentration for 50% growth inhibition: 19000 nM
Compound 4: the middle estimate sits 1.3-fold (0.12 log units) above what was measured; low and high end bracket the measured number.
By their numbers in this assay, from the lowest: compounds 4, 2 and 1 (each within the scatter of the next); then compound 3.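

In this assay the swap of pentan-3-yl for 2-fluorophenyl on a double-bonded chain carbon bound to a double-bonded chain carbon gives a 2.7-fold lower number from compound 3 to compound 4 (0.44 log units; beyond the scatter) as a modest step, with the acetoxymethyl branch and the benzoyl part held fixed. Among the compounds shown here, this is the first matched reading at this position, and it shows that the position responds to a change of group, with the aromatic ring tolerated and the number lower. The pair cannot separate the effect of the ring from that of the fluorine, and no measured information explains the step.

Phenyl without fluorine at this place would separate the ring from the fluorine, while a 4-fluorophenyl would test where the fluorine sits. A hydroxymethyl in place of the acetoxymethyl branch would show what that retained branch contributes.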